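This account rests on a few compounds, and the source may have more. Where it says the series, first, only, none or still open, it means among the compounds named here.

Three esters share one core. Compound 1 `COC(=O)C1=C(C)N(C)C(=O)NC1c1ccoc1` gives 7% in an assay on membranes from HEK293 cells for displacement of a labelled ligand from adenosine receptor A2b (Homo sapiens), read by scintillation counting, with a stated time of 30 min, tested at 1 uM; on this read-out lower numbers stand for less inhibition and higher numbers for more inhibition at the one concentration tested (going by the name of the read-out). Compound 2 `CCCOC(=O)C1=C(C)N(C)C(=O)NC1c1ccoc1` gives 2% in this assay, and compound 3 `CC1=C(C(=O)OCC(C)C)C(c2ccoc2)NC(=O)N1C` gives 1%. Compound 3 stands alongside the other two: a number 6 percentage points lower from compound 1 to compound 3 (within the scatter) and a number 1 percentage points lower from compound 2 to compound 3 (within the scatter), just as a number 5 percentage points lower from compound 1 to compound 2 (within the scatter). Compound 4 `CC1=C(C(=O)OC(C)(C)C)C(c2ccoc2)NC(=O)N1C` differs from compound 3 by tert-butyl in place of isobutyl on an oxygen next to a carbonyl group. Among the compounds with values here, every measured step so far sits at this same oxygen next to a carbonyl group, and none moved the number beyond the scatter. Compound 4 is therefore expected to give a number 1 percentage points higher from compound 3 to compound 4 (within the scatter) because a number 5 percentage points lower from compound 1 to compound 2 (within the scatter) and a number 6 percentage points lower from compound 1 to compound 3 (within the scatter) both stayed within the scatter. Compound 4 is estimated at 2%, with a range from -6% to 10%.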

Compound 4, a percentage reported as inhibition, at one concentration (the size of the read-out at that concentration, not a potency): 16%
Compound 4: the middle estimate sits 14 percentage points below what was measured; measured number above the stated range.
By their numbers in this assay, from the lowest: compounds 3, 2, 1 and 4 (each within the scatter of the next, the first and the last beyond it).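

In this assay a change on this oxygen next to a carbonyl group now passes the scatter: tert-butyl in place of isobutyl, the same atoms joined differently, gives a number 15 percentage points higher from compound 3 to compound 4 (beyond the scatter) and tert-butyl in place of propyl gives a number 14 percentage points higher from compound 2 to compound 4 (beyond the scatter). Against methyl there is only a number 9 percentage points higher from compound 1 to compound 4 (within the scatter) so only propyl and isobutyl are separated from tert-butyl. Nothing shown gives a reason for this. As far as these compounds go, whether isopropyl or cyclohexyl on this oxygen would behave like tert-butyl stays open, as does whether an amide in place of the ester would do the same.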